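This account rests on a few compounds, and the source may have more. Where it says the series, first, only, none or still open, it means among the compounds named here.

Compound 1 `CC[C@@H](Nc1c(C#N)c(-c2ccc(-c3ccccc3N(C)C)cc2)nc2cnccc12)C(N)=O` has been measured in a physicochemical assay for lipophilicity, read by HPLC, at pH 7.5 (a higher number here means a more lipophilic compound, a lower number a more polar compound), and gives 3.2, the second highest of the three numbers at hand. Compound 3 `CCCCC(Nc1c(C#N)c(-c2ccc(-c3ccccc3OCC)cc2)nc2cnccc12)C(N)=O` gives 3.6 in this assay, a value beyond the scatter above that of compound 1, while compound 2 `CCOc1ccccc1-c1ccc(-c2nc(NC(C)C(=O)O)c3ccncc3n2)cc1` gives 2.1, farther off in the other direction. Compound 4 `CC[C@@H](Nc1c(C#N)c(-c2ccc(Br)cc2)nc2cnccc12)C(N)=O` has not yet been measured in this assay. It differs from compound 1 in one place: bromo in place of 2-(dimethylamino)phenyl on an aromatic carbon. The group that leaves carries one six-membered aromatic ring of carbon only and one hydrogen-bond acceptor; what enters is a single bromine. A step downward and beyond the scatter is expected, a number 1.00 log units lower from compound 1 to compound 4 (beyond the scatter). Compound 4 is therefore estimated to give 2.2, with a range from 1.7 to 2.7.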

Compound 4, distribution coefficient: 2.2
Compound 4: middle estimate and measured number agree at the digits printed; measured number inside the range.
By their numbers in this assay, from the lowest: compounds 2 and 4 (each within the scatter of the next); then compound 1; then compound 3.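

Among these compounds, replacing 2-(dimethylamino)phenyl with bromo on this aromatic carbon gives the first comparison here between compounds that differ in one place, and this assay records a number 1.00 log units lower from compound 1 to compound 4 (beyond the scatter). The number in this assay therefore shifts with the group at this position alone, while the rest of compound 1 stays unchanged. Nothing at hand gives a cause for this step. The compounds shown leave open how a plain phenyl or a single chlorine at this carbon would read, and so whether the step follows the ring, the dimethylamino group or the bromine.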